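A Larger Group at the Same Aromatic Carbon

The source may report more compounds than this note shows. Statements on the series, on what has been measured and on what is new or still open speak of the compounds shown alone.

Compound 1 `N/C(=N/O)c1ccc2[nH]c(-c3cccc(-c4ccccc4O)c3O)cc2c1`: 15%
Compound 2 `CC(C)ONC(=N)c1ccc2[nH]c(-c3cccc(-c4ccccc4O)c3O)cc2c1`: 10%

Of the compounds shown here, two have been measured in an in vivo ADME assay on the whole organism (strain Sprague-Dawley) for pharmacokinetics, with Rattus norvegicus as the target; a higher number here means that a larger share of the oral dose reaches the circulation, a lower number that a smaller share of the oral dose reaches the circulation. Going by the values given here, compound 1 holds the higher of the two numbers, though the one measured step, a number 5 percentage points lower from compound 1 to compound 2 (within the scatter), lies within the scatter of repeated measurements, so the two compounds cannot be told apart with confidence.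

Compound 3 `CC(C)(C)ONC(=N)c1ccc2[nH]c(-c3cccc(-c4ccccc4O)c3O)cc2c1` is not yet measured. It differs from compound 1 in one place: a group of 8 heavy atoms (5 carbon, 2 nitrogen, 1 oxygen; no ring) in place of a group of 4 heavy atoms (1 carbon, 2 nitrogen, 1 oxygen; no ring), on an aromatic carbon. Among the compounds with values here, the only measured step that bears on this change is the move from compound 1 to compound 2, where a group of seven heavy atoms replaced the same four-atom group at the same aromatic carbon and gave a number 5 percentage points lower from compound 1 to compound 2 (within the scatter). Compound 3 extends that replacement by one further carbon. On this evidence, compound 3 is expected to show a number 5 percentage points lower from compound 1 to compound 3 (within the scatter), a step not beyond the scatter. Compound 3 is therefore estimated at 10%, within a range of 3% to 20%.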

Compound 3, oral bioavailability: 38%
Compound 3: middle estimate off by 28 percentage points, on the low side; the whole stated range lies below it.
By their numbers in this assay, from the lowest: compounds 2 and 1 (each within the scatter of the next); then compound 3.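

In this assay, this aromatic carbon of the shared core proves able to take a larger group with a measurable gain: the eight-atom group in place of the four-atom group gives a number 23 percentage points higher from compound 1 to compound 3 (beyond the scatter), a result the seven-atom group of compound 2 did not foreshadow. The decisive change is small, since methyl in place of hydrogen on the saturated chain carbon gives a number 28 percentage points higher from compound 2 to compound 3 (beyond the scatter), so the outcome at this position depends on that single methyl and not simply on a larger group being present. Nothing shown accounts for this rise.

The compounds shown leave open whether a longer straight chain or a cyclopropyl ring on the same oxygen would give a similar number. They also leave open how a carboxylic acid or an amine at this aromatic carbon would compare.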